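Terminal aryl variation on the shared core, bile acid receptor agonism

The source may hold more compounds than are shown below. What is called first, only, known or untested is meant among the compounds shown, and "the series" means these compounds.

compound 1 `COc1cccc(-c2ccc([C@H]3S[C@@H](C)C(=O)Nc4c3c(C)nn4-c3ccccc3C)cc2)c1`: 1800 nM
compound 2 `COC(=O)c1cccc(-c2ccc([C@H]3S[C@@H](C)C(=O)Nc4c3c(C)nn4-c3ccccc3C)cc2)c1`: "not active" (no number reported)
compound 3 `CCOc1cccc(-c2ccc([C@H]3S[C@@H](C)C(=O)Nc4c3c(C)nn4-c3ccccc3C)cc2)c1`: 3500 nM

In an assay on isolated protein for agonist activity at Bile acid receptor (Homo sapiens), read by AlphaScreen, with a stated time of 30 min (on this read-out higher numbers stand for an effect only at larger amounts of compound and lower numbers for an effect already at smaller amounts), compound 1 gives 1800 nM. Compound 2 is recorded only as "not active" (no number reported), with no number attached. Compound 3 gives 3500 nM. Going by the values given here, of the two numbers available compound 3 holds the higher one, but the single step connecting them, a 1.9-fold higher number from compound 1 to compound 3 (0.29 log units; within the scatter), lies within the scatter, so compounds 1 and 3 are not distinguished on this read-out.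

Compound 4 `Cc1ccccc1-n1nc(C)c2c1NC(=O)[C@H](C)S[C@@H]2c1ccc(-c2ccc(C(=O)O)cc2)cc1` is not yet measured. It differs from compound 3 by 4-carboxyphenyl in place of 3-ethoxyphenyl on an aromatic carbon. Among the compounds with values here, no measured step bears directly on this change: the only step, a 1.9-fold higher number from compound 1 to compound 3 (0.29 log units; within the scatter), concerns the ether chain alone and is within the scatter, and compound 2 shows only that a close analogue can leave this assay without a number. The expectation for compound 4 is therefore broad. Compound 4 is estimated at 3000 nM, with a range from 600 nM to 15000 nM. This corresponds to an expected step of a 1.2-fold lower number from compound 3 to compound 4 (0.07 log units; within the scatter), no clearer than the scatter, and there is a real chance that compound 4, like compound 2, returns no number at all.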

Compound 4, half-maximal effective concentration: "not active" (no number reported)
Compound 4 has no reported number here; the estimate stays without a comparison.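

In this assay, going by these compounds alone, compound 4 is recorded as "not active" (no number reported), like compound 2, so no step from compound 3 to compound 4 can be read. The compounds shown leave open how far compound 2 and compound 4 lie from compound 1 and compound 3 on this read-out. No measured evidence bears on this result.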